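Piperidine Sulfonamides: Swapping an Amide Link for Azepane

The compounds below may be only part of what the source reports. "The series", "measured", "known", "first", "only" and "open" are said of these compounds alone.

Measured so far:
- compound 2 `Cc1cc(C)c(S(=O)(=O)N2CCC(C(=O)N3CCC(C)CC3)CC2)c(C)c1`: > 5000 nM
- compound 1 `COc1ccc(-c2cccc(S(=O)(=O)N3CCC(N4CCC(C)CC4)CC3)c2)cc1`: 23 nM

In a functional assay on DLD-1 cells (Homo sapiens) for antiproliferative activity, read by CellTiter-Glo, with a stated time of 72 h (on this read-out lower numbers stand for stronger inhibition and higher numbers for weaker inhibition), compound 2 reaches only the assay limit, (the limit of > 5000 nM in this assay, at which 1 of the 2 values shown sits), so no number is known for it. Compound 1, in this assay, gives 23 nM. Compound 3 `Cc1cc(C)c(S(=O)(=O)N2CCC(N3CCCCCC3)CC2)c(C)c1` differs from compound 2 by azepan-1-yl in place of (4-methylpiperidin-1-yl)carbonyl on a saturated ring carbon. Within the data shown here, with no measured step of this kind, the direction is a guess; still, compound 3 is expected to become a measurable value, an estimated gain an at least 12-fold lower number from compound 2 to compound 3 (1.09 log units; beyond the scatter). Compound 3 is estimated at 400 nM, within 60 nM to 3000 nM.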

Compound 3, half-maximal inhibitory concentration: 5.3 nM
Compound 3: the middle estimate sits 75-fold (1.88 log units) above what was measured; measured number below the stated range.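

Swapping the group on this saturated ring carbon turns out to matter greatly: in this assay the change gives an at least 940-fold lower number from compound 2 to compound 3 (2.97 log units; beyond the scatter), the first measured step at this position. The size of that step is only a lower bound, since the value of compound 2 is a limit and not a number: the limit of > 5000 nM in this assay, at which 1 of the 3 values shown sits.

The carbonyl leaves and the ring size changes in the same step, so the compounds shown cannot say which of the two carries the effect. A smaller ring such as pyrrolidin-1-yl, or an open-chain dimethylamino group, on this carbon would help separate them.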